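The source may hold more compounds than are shown below. What is called first, only, known or untested is meant among the compounds shown, and "the series" means these compounds.

Of the compounds shown here, three sharing one core have been tested in a functional assay on U-87MG ATCC cells for cytotoxicity against U-87 MG (Homo sapiens), read by colorimetric assay and MTT assay (a lower number here means a stronger inhibitor, a higher number a weaker inhibitor), and they differ only in the group on a saturated chain carbon bound to an aromatic nitrogen. Compound 1 `CCN(CC)C(=O)Cn1c(=O)c(-c2ccc(OC)cc2)cc2c(OC)cc(OC)cc21`, with diethylcarbamoyl there, gives 10000 nM. Compound 2 `COc1ccc(-c2cc3c(OC)cc(OC)cc3n(CC#N)c2=O)cc1`, with cyano at that place, gives 10000 nM. Compound 3 `COc1ccc(-c2cc3c(OC)cc(OC)cc3n(CC(=O)OCc3ccccc3)c2=O)cc1`, with benzyloxycarbonyl, gives 10000 nM, which puts it level with the other two.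

The next compound, compound 4 `COC(=O)CCn1c(=O)c(-c2ccc(OC)cc2)cc2c(OC)cc(OC)cc21`, has (methoxycarbonyl)methyl in place of benzyloxycarbonyl on that same carbon: (methoxycarbonyl)methyl in place of benzyloxycarbonyl on a saturated chain carbon bound to an aromatic nitrogen. The difference can also be read as (benzyloxycarbonyl)methyl changing to 2-(methoxycarbonyl)ethyl.

All three measured steps bear on this change, since each swaps the group at this place. The data show no change at the digits printed from compound 1 to compound 2 (within the scatter), no change at the digits printed from compound 1 to compound 3 (within the scatter) and no change at the digits printed from compound 2 to compound 3 (within the scatter). So three quite different groups have produced no movement at all in this assay. This is a small set, and none of its members carries the 2-(methoxycarbonyl)ethyl group, so a surprise remains possible. Even so, the data offer no reason to predict a shift in either direction. The expected result is no change at the digits printed from compound 3 to compound 4 (within the scatter), with nothing beyond the scatter. Compound 4 is estimated at 10000 nM, within a range of 4000 nM to 20000 nM.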

Compound 4, half-maximal inhibitory concentration: 10000 nM
Compound 4: middle estimate and measured number agree at the digits printed; low and high end bracket the measured number.
By their numbers in this assay, from the lowest: compounds 1, 2, 3 and 4 (each within the scatter of the next).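

In this assay, the step to the new group gives no change at the digits printed from compound 3 to compound 4 (within the scatter), so trading benzyloxycarbonyl, with its six-membered aromatic ring of carbon only and 10 heavy atoms, for (methoxycarbonyl)methyl, with no ring and 5 heavy atoms, leaves the reading where it stood. For the compounds shown here, the comparisons with the other two groups agree, with no change at the digits printed from compound 2 to compound 4 (within the scatter) and no change at the digits printed from compound 1 to compound 4 (within the scatter), and this extends the flat picture to a case the earlier compounds did not cover: the same difference read one bond further out, (benzyloxycarbonyl)methyl to 2-(methoxycarbonyl)ethyl, also has no visible effect on the number. No supporting measurement accompanies these four compounds that could account for this uniform result.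

Since all four compounds read alike, they cannot show whether any group at this place is able to move the number in this assay, or whether the shared core alone sets it. On these data alone, it remains open whether a carboxylic acid or an amine on this chain, or a longer chain, would read any differently.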